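The compounds below may be only part of what the source reports. "The series", "measured", "known", "first", "only" and "open" are said of these compounds alone.

The measured compounds:

compound 1, `CN(C)CCn1cnnc1-c1cc(Oc2ccc(NC(=O)N/N=C/c3ccc(O)cc3)cc2F)ccn1`: 7750 nM
compound 2, `CN(C)CCn1cnnc1-c1cc(Oc2ccc(NC(=O)N/N=C/c3ccc(O)cc3O)cc2F)ccn1`: 15400 nM

In a functional assay on U-87MG ATCC cells (Homo sapiens) for cytotoxicity, read by MTT assay, with a stated time of 72 h (on this read-out lower numbers stand for stronger inhibition and higher numbers for weaker inhibition), compound 2 gives 15400 nM, the highest of the two numbers recorded. Within the data shown here, its nearest neighbour is compound 1, which in this assay gives 7750 nM; the one measured step between them, a 2.0-fold higher number from compound 1 to compound 2 (0.30 log units; within the scatter), adds a hydroxy group to the aromatic ring that carries the hydrazone carbon and stays within the scatter.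

Compound 3, `Cc1cc(/C=N/NC(=O)Nc2ccc(Oc3ccnc(-c4nncn4CCN(C)C)c3)c(F)c2)cc(C)c1O`, differs from compound 2 in one place: 4-hydroxy-3,5-dimethylphenyl in place of 2,4-dihydroxyphenyl on a carbon with a double bond to nitrogen. Among the measured compounds shown here, the only measured step that touches this ring is a 2.0-fold higher number from compound 1 to compound 2 (0.30 log units; within the scatter), which shows that adding or removing a hydroxy group there changes the number by no more than the scatter. For the measured compounds named here, no measured step covers the methyl groups that enter. On this basis the expected step is a 1.6-fold lower number from compound 2 to compound 3 (0.21 log units; within the scatter), that is, none beyond the scatter, with a slight lean toward a lower number in line with the loss of the second hydroxy group. Compound 3 is therefore expected to give about 9500 nM, with a range from 3500 nM to 26000 nM.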

Compound 3, half-maximal inhibitory concentration: 7710 nM
Compound 3: the middle estimate sits 1.2-fold (0.09 log units) above what was measured; low and high end bracket the measured number.
By their numbers in this assay, from the lowest: compounds 3, 1 and 2 (each within the scatter of the next).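

In this assay the swap of 2,4-dihydroxyphenyl for 4-hydroxy-3,5-dimethylphenyl gives a 2.0-fold lower number from compound 2 to compound 3 (0.30 log units; within the scatter) and the swap of 4-hydroxyphenyl for the same group gives a 1.0-fold lower number from compound 1 to compound 3 (0.00 log units; within the scatter) on the same read-out. The earlier compounds had shown only what a hydroxy group does on this ring, whereas these steps show that a ring carrying methyl groups also stays within the scatter of both hydroxylated rings, so the number at this position has not yet moved beyond the scatter with any of the three rings shown. Nothing measured alongside these numbers bears on why the ring can be changed in these ways with so little effect.

From the compounds shown here alone, all three rings keep the hydroxy group named at the 4 position in 4-hydroxyphenyl, so it remains open whether a plain phenyl ring, or a ring with a methoxy group, an amine or a carboxylic acid in its place, would stay within the scatter. Also open, going by these compounds, is whether larger groups than methyl, such as tert-butyl, would leave the number as little changed.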